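A few compounds are considered here, and "the series" means these few. Any claim that something is new, unique, unknown or untested is made for them only; others in the source may bear on it.

Compound 1 `Cc1ccc(NS(=O)(=O)c2ccc(N3CCNC3=O)cc2)cc1` is the reference point. Going by the values given here, in a functional assay on M21 cells (Homo sapiens) for antiproliferative activity, read by sulforhodamine B assay, with a stated time of 48 h (a higher number here means a weaker inhibitor, a lower number a stronger inhibitor), compound 1 gives 260 nM, the only plain number among the two values shown. Compound 2 `CC(C)(C)c1ccc(NS(=O)(=O)c2ccc(N3CCNC3=O)cc2)cc1` carries a tert-butyl in place of the methyl on an aromatic carbon. In this assay compound 2 reaches only the limit > 1000 nM. The step of an at least 3.8-fold higher number from compound 1 to compound 2 (0.58 log units; beyond the scatter) therefore marks a weakening that is at least modest, because the number for compound 2 sits at the limit (the limit of > 1000 nM in this assay, at which 1 of the 2 values shown sits).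

Compound 3 `Cc1cccc(NS(=O)(=O)c2ccc(N3CCNC3=O)cc2)c1C` alters the same aromatic ring in a different way: 2,3-dimethylphenyl in place of 4-methylphenyl on a sulfonamide nitrogen. Among the compounds with values here, no measured pair matches this change exactly; the one step that touches the same ring, an at least 3.8-fold higher number from compound 1 to compound 2 (0.58 log units; beyond the scatter), shows that enlarging the substituent there weakened inhibition, so its bearing is indirect. The expectation is a small rise in the number, near the edge of the scatter, as the step of a 1.9-fold higher number from compound 1 to compound 3 (0.28 log units; within the scatter). Compound 3 is thus expected to give about 500 nM in this assay, within 200 nM to 1500 nM.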

Compound 3, half-maximal inhibitory concentration: 110 nM
Compound 3: the middle estimate sits 4.5-fold (0.66 log units) above what was measured; measured number below the stated range.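

Compound 3 shows that a larger group on the sulfonamide nitrogen need not weaken this series: in this assay the change from 4-methylphenyl to 2,3-dimethylphenyl gives a 2.4-fold lower number from compound 1 to compound 3 (0.37 log units; beyond the scatter). Enlarging what sits on this ring therefore has no single direction, since compound 2 goes the other way, with an at least 3.8-fold higher number from compound 1 to compound 2 (0.58 log units; beyond the scatter), while compound 3 improves on the reference. The full size of the step to compound 2 cannot be read, because its number is a limit and not a measured value: the limit of > 1000 nM in this assay, at which 1 of the 3 values shown sits.

What stays open is which part of the change in compound 3 matters, since it adds a methyl and also alters where the methyl groups sit, and the compounds shown include no 2-methylphenyl or 3-methylphenyl group that could separate these two effects. Going by these compounds, it is equally open how this ring would respond to groups of another kind, such as a methoxy, a chlorine or an amine, and whether a third methyl would extend the gain or reverse it.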